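The compounds below may be only part of what the source reports. "The series", "measured", "known", "first", "only" and "open" are said of these compounds alone.

Compound 2, with the structure `COc1ccc(C(=O)C2=C(O)C(=O)N(c3ccc(-c4ccon4)cc3)C2c2ccccc2OC)cc1`, is the weakest of the three measured compounds on the read-out that tracks how long a compound survives in the body: in an ADME assay on the whole organism (Rattus norvegicus) for metabolic stability (on this read-out higher numbers stand for a longer-lived compound and lower numbers for a shorter-lived compound), compound 2 gives 0.5 h. Its two neighbours differ from it in one place each. Compound 1, `CCC(CC)C1C(C(=O)c2ccc(OC)cc2)=C(O)C(=O)N1c1ccc(-c2ccon2)cc1`, gives 4.2 h in this assay, and the change an 8.4-fold lower number from compound 1 to compound 2 (0.92 log units; beyond the scatter). Compound 3, `COc1ccccc1C1C(C(=O)C(C)(C)C)=C(O)C(=O)N1c1ccc(-c2ccon2)cc1`, gives 2.6 h, and the change a 5.2-fold higher number from compound 2 to compound 3 (0.72 log units; beyond the scatter). Both of those steps are larger than the usual scatter, so compound 2 clearly sits at the bottom of this small set.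

Compound 4, `COc1ccc(C(=O)C2=C(O)C(=O)N(c3ccc(-c4ccon4)cc3)C2c2ccccc2OCCO)cc1`, differs from compound 2 by hydroxymethyl in place of hydrogen on a saturated chain carbon bound to an oxygen on an aromatic ring. Neither of the measured steps touches this place: one swaps the group on the saturated ring carbon, the other swaps the group on the carbonyl carbon, and nothing measured alters the chain hanging from the aromatic oxygen. Going by the values given here, there is therefore no measured step that bears directly on this change, and the expectation rests only on the small size of the addition. The estimate is that the step of a 1.4-fold higher number from compound 2 to compound 4 (0.15 log units; within the scatter) will stay within the scatter. Compound 4 is accordingly expected to give about 0.7 h, with a plausible range from 0.3 h to 1.6 h.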

Compound 4, half-life: 0.5 h
Estimate against measurement, compound 4: 1.4-fold (0.15 log units) above, within the range that was stated.
By their numbers in this assay, from the lowest: compounds 2 and 4 (each within the scatter of the next); then compounds 3 and 1 (each within the scatter of the next).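

Lengthening the methoxy on the aromatic ring to 2-hydroxyethoxy, which adds hydroxymethyl on a saturated chain carbon bound to an oxygen on an aromatic ring, gives no change at the digits printed from compound 2 to compound 4 (within the scatter) in this assay. Going by these compounds alone, this is the first look at this chain, and it shows that the place can carry one more hydrogen-bond donor and acceptor without the number moving beyond the usual scatter, at least on the core of compound 2. The large gap to the pentan-3-yl compound also remains, since 2-(2-hydroxyethoxy)phenyl in place of pentan-3-yl gives an 8.4-fold lower number from compound 1 to compound 4 (0.92 log units; beyond the scatter), matching the size of an 8.4-fold lower number from compound 1 to compound 2 (0.92 log units; beyond the scatter), and no supporting data are available to explain either the flat step or this gap.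

From the compounds shown here alone, it remains open whether a different end on this chain, such as an amine, a carboxylic acid or a longer chain, would also leave the number unchanged. Going by these compounds, it is also open whether the same hydroxymethyl addition would give the same result on compound 3, which carries tert-butyl on the carbonyl carbon.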